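The compounds below may be only part of what the source reports. "The series", "measured", "known", "first", "only" and "open" are said of these compounds alone.

Measured so far:
Compound 1 `CCCCCCCCCCOc1cc(OC)c(Br)cc1C(C)=O`: 29700000 nM
Compound 2 `CCCCCCCCCCCCCCOc1cc(OC)c(Br)cc1C(C)=O`: 13200000 nM

Among the measured compounds shown here, in a functional assay, with a stated time of 10 min (a higher number here means a weaker inhibitor, a lower number a stronger inhibitor), compound 1 gives 29700000 nM, the higher of the two numbers so far, which makes it the weaker inhibitor of this pair. Compound 3 `CCCCCCCCCCOc1cc(OC)ccc1C(C)=O` keeps the rest of compound 1 and changes one spot: hydrogen in place of bromo on an aromatic carbon.

For the measured compounds named here, the only measured step is a 2.3-fold lower number from compound 1 to compound 2 (0.35 log units; beyond the scatter). Going by the values given here, that step lies on the saturated chain, so no measured step tests the loss of bromo. Among the compounds with values here, its modest size is the sole guide, and the direction stays open, with a slight lean towards a higher number in this assay.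

The step expected is a 1.3-fold higher number from compound 1 to compound 3 (0.13 log units; within the scatter). For compound 3 the estimated value is 40000000 nM, with an expected range from 12000000 nM to 130000000 nM.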

Compound 3, half-maximal inhibitory concentration: 57400000 nM
For compound 3 the middle estimate is 1.4-fold (0.16 log units) below the measured one, and the stated range covers the measured number.
By their numbers in this assay, from the lowest: compound 2; then compounds 1 and 3 (each within the scatter of the next).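

Swapping bromo for hydrogen on this aromatic carbon, which sits ortho to a methoxy group and meta to an acetyl group, gives the first measured test of this position in this assay (a 1.9-fold higher number from compound 1 to compound 3 (0.29 log units; within the scatter)). Compounds 1 and 3 therefore cannot be told apart in this assay, so the bromo is not shown to matter here, on the core of compound 1 with its chain unchanged. Nothing available explains this result.

On these data alone, whether a different group on this carbon, such as chloro, an amine or a carboxylic acid, would move the number beyond the scatter remains open. As far as these compounds go, it is also open whether the same swap would give a similar result with the longer chain of compound 2.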